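The source may hold more compounds than are shown below. What is called first, only, known or untested is meant among the compounds shown, and "the series" means these compounds.

Compound 3 `COC1Cc2c(cnn2-c2ccccc2)C2(CCN(Cc3ccco3)CC2)O1` gives 2.2 nM in an assay for displacement of a labelled ligand from Sigma non-opioid intracellular receptor 1 (Cavia porcellus), read by scintillation counting, with a stated time of 180 min (a lower number here means a stronger inhibitor, a higher number a weaker inhibitor), the lowest of the two numbers in hand; compound 1 `Cn1ncc2c1CCOC21CCN(N2CCC(c3ccccc3)CC2)CC1` gives 7 nM in this assay. Compound 2 `COC1Cc2c(cnn2-c2ccccc2)C2(CCNCC2)O1` reaches only a limit in this assay, > 1000 nM. Among the compounds with values here, the one measured step, an at least 450-fold lower number from compound 2 to compound 3 (2.65 log units; beyond the scatter), shows how much a group on the ring nitrogen matters against a bare nitrogen, but it does not compare one group with another. Compound 4 `CCCN1CCC2(CC1)OC(OC)Cc1c2cnn1-c1ccccc1` keeps a substituent on that nitrogen, only smaller: ethyl in place of furan-2-yl on a saturated chain carbon bound to an amine nitrogen in a ring. Within the data shown here, with no measured step comparing such groups, a moderate loss is expected, well short of the fall seen toward compound 2, as a 9.1-fold higher number from compound 3 to compound 4 (0.96 log units; beyond the scatter). Compound 4 is therefore estimated at 20 nM, within 5 nM to 80 nM.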

Compound 4, inhibition constant: 33 nM
Compound 4: the middle estimate sits 1.7-fold (0.22 log units) below what was measured; low and high end bracket the measured number.
By their numbers in this assay, from the lowest: compound 3; then compound 1; then compound 4. At a limit, above all of these: compound 2.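

Even the small propyl group on the ring nitrogen gives an at least 30-fold lower number from compound 2 to compound 4 (1.48 log units; beyond the scatter), so a plain saturated chain there is already much better than hydrogen. Within the data shown here, the kind of group matters as well: a 15-fold higher number from compound 3 to compound 4 (1.18 log units; beyond the scatter), the first measured comparison of one group with another at this place, and it favours (furan-2-yl)methyl over propyl. Compound 2 stands at a limit and not at a number: the limit of > 1000 nM in this assay, at which 1 of the 4 values shown sits.

Still open, going by these compounds, is whether the gain belongs to the furan ring as such or to any group with more atoms. A benzyl group or a butyl chain on that nitrogen would help separate the two.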